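The source may report more compounds than this note shows. Statements on the series, on what has been measured and on what is new or still open speak of the compounds shown alone.

Compound 1 `CS(=O)(=O)Nc1cccc2c1CCC2c1ncc[nH]1` is the reference point of this account. In a functional assay on CHO cells for agonist activity at Alpha-1A adrenergic receptor (Homo sapiens), read by FLIPR and calcium flux (on this read-out lower numbers stand for smaller maximal responses and higher numbers for larger maximal responses), compound 1 gives 87%, the highest of the three numbers that have been recorded, though its lead is not uniform. Compound 3 `Cc1ccc2c(c1NS(C)(=O)=O)CCC2c1ncc[nH]1` gives 83%, and the step of a number 4 percentage points lower from compound 1 to compound 3 (within the scatter) lies within the scatter, so the two compounds cannot be ordered. Compound 2 `Cc1c(OCC2=NCCN2)ccc(Cl)c1NS(C)(=O)=O`, which is built on a different frame, gives 60%, a number clearly below that of compound 1.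

Compound 4 `CCS(=O)(=O)Nc1cccc2c1CCC2c1ncc[nH]1` is the compound still to be measured. It differs from compound 1 by methyl in place of hydrogen on a saturated chain carbon bound to a sulfonyl sulfur.

Within the data shown here, only one measured step in this assay involves a single added methyl, and that is a number 4 percentage points lower from compound 1 to compound 3 (within the scatter); it sits on an aromatic carbon of the core rather than on the sulfonyl substituent, so it bears on compound 4 only loosely. That step was small. Among the measured compounds shown here, no measured pair shows the methyl-to-ethyl change on the sulfonamide itself, so the expectation rests on the modest size of the one analogous change.

Compound 4 is therefore expected to give about 84% in this assay, between 70% and 97%. The expected step of a number 3 percentage points lower from compound 1 to compound 4 (within the scatter) is estimated to stay within the scatter.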

Compound 4, largest response reached (Emax), in percent of the reference or control that the assay uses: 86%
Beside the measured number, compound 4's estimate is 2 percentage points below it, and the stated range covers the measured number.
By their numbers in this assay, from the lowest: compound 2; then compounds 3, 4 and 1 (each within the scatter of the next).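

Among these compounds, all the earlier compounds carry methylsulfonyl, so the step of a number 1 percentage points lower from compound 1 to compound 4 (within the scatter) in this assay is the first reading of a change on the sulfonyl substituent itself: methanesulfonamido gives way to (ethylsulfonyl)amino with no difference that this read-out can resolve. Taken with the step of a number 4 percentage points lower from compound 1 to compound 3 (within the scatter), which sits on an aromatic carbon, it shows that a methyl in place of hydrogen at either of these two places leaves the maximal response within the scatter of compound 1, and these two steps are the only evidence for that pattern. Nothing available explains why the response holds at this position, and no measurement of any property of the added methyl bears on it.

From the compounds shown here alone, whether this position accepts anything larger than ethyl remains open, since a longer chain such as propyl, a branched isopropyl or a cyclopropyl ring on the sulfonyl sulfur would probe it further. The compounds shown also leave open how a chain ending in an amine or a carboxylic acid would behave here, or whether trifluoromethyl could stand in place of the methyl of compound 1.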